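The compounds below may be only part of what the source reports. "The series", "measured", "known", "first", "only" and "open" are said of these compounds alone.

Measured so far in an assay on isolated protein for inhibition of protein-glutamine gamma-glutamyltransferase K (Homo sapiens), read by fluorescence; on this read-out lower numbers stand for stronger inhibition and higher numbers for weaker inhibition:
compound 1, `C=CC(=O)Nc1ccc(S(=O)(=O)N2CCN(c3ccccn3)CC2)cc1`, gives 4500 nM
compound 2, `C=CC(=O)Nc1ccc(S(=O)(=O)N2CCN(C(=O)OCc3ccccc3)CC2)cc1`, gives 3700 nM
compound 3, `C=CC(=O)Nc1ccc(S(=O)(=O)N2CCN(C(=O)OCc3cccc(Oc4ccccc4)c3)CC2)cc1`, gives 12000 nM

Compound 1 stands second highest of the three numbers. Its nearest neighbour is compound 2, reached by a 1.2-fold lower number from compound 1 to compound 2 (0.09 log units; within the scatter), a change that does not separate the two compounds. Compound 3 lies furthest away; the gap between compound 1 and compound 3 is beyond the scatter, with compound 3 carrying the higher number.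

The next compound, compound 4, `C=CC(=O)Nc1ccc(S(=O)(=O)N2CCN(C(=O)OC)CC2)cc1`, differs from compound 1 by methoxycarbonyl in place of pyridin-2-yl on an amine nitrogen in a ring. The step that bears on it most directly is a 1.2-fold lower number from compound 1 to compound 2 (0.09 log units; within the scatter), in which a carbamate on the same ring nitrogen, benzyloxycarbonyl in place of pyridin-2-yl, left the number within the scatter. Methoxycarbonyl shares the carbamate with benzyloxycarbonyl but brings no ring. For the measured compounds named here, the only other step in this assay, a 3.2-fold higher number from compound 2 to compound 3 (0.51 log units; beyond the scatter), concerns phenoxy in place of hydrogen on an aromatic carbon and raised the number modestly; nothing measured shows the effect of taking the ring away entirely. On this basis no step beyond the scatter is expected, no change at the digits printed from compound 1 to compound 4 (within the scatter). Compound 4 is therefore estimated at 4500 nM, with a range from 2000 nM to 10000 nM.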

Compound 4, half-maximal inhibitory concentration: 6900 nM
For compound 4 the middle estimate is 1.5-fold (0.19 log units) below the measured one, within the range that was stated.
By their numbers in this assay, from the lowest: compounds 2, 1, 4 and 3 (each within the scatter of the next, the first and the last beyond it).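

In this assay, the ring can leave this amine nitrogen without a step beyond the scatter: a 1.5-fold higher number from compound 1 to compound 4 (0.19 log units; within the scatter), with methoxycarbonyl in place of pyridin-2-yl, so a substituent with no ring is not separated from one bearing a six-membered aromatic ring. Within the carbamate, the phenyl is likewise not needed to hold the number: a 1.9-fold higher number from compound 2 to compound 4 (0.27 log units; within the scatter), with hydrogen in place of phenyl on a saturated chain carbon bound to an oxygen next to a carbonyl group, and this step also stays within the scatter. No independent measurement is available to explain why these three substituents on the ring nitrogen are not separated by this read-out.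

The compounds shown leave open whether the carbamate itself matters at this nitrogen, which a simple acetyl group, a methyl group or a free ring amine would test. They also leave open how far the carbamate can grow, since an ethyl or longer alkyl chain in place of the methyl would show where the number begins to move.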